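Hydrogen for amino on the shared core: compound 3 expected

The source may hold more compounds than are shown below. What is called first, only, known or untested is meant among the compounds shown, and "the series" means these compounds.

Measured so far:
- compound 1, `COc1ncnc2c1c(-c1cccs1)cn2[C@@H]1O[C@H](CO)[C@@H](O)[C@H]1O`: 440 nM
- compound 2, `COc1nc(N)nc2c1c(-c1ccco1)cn2[C@@H]1O[C@H](CO)[C@@H](O)[C@H]1O`: > 20000 nM

Compound 1, `COc1ncnc2c1c(-c1cccs1)cn2[C@@H]1O[C@H](CO)[C@@H](O)[C@H]1O`, carries hydrogen rather than amino on the shared core and in a functional assay on HCT-116 cells (Homo sapiens), read by MTT assay, with a stated time of 72 h (on this read-out higher numbers stand for weaker inhibition and lower numbers for stronger inhibition), compound 1 gives 440 nM. Compound 2, `COc1nc(N)nc2c1c(-c1ccco1)cn2[C@@H]1O[C@H](CO)[C@@H](O)[C@H]1O`, carries the amino group and the furan. In this assay compound 2 stands at the limit of > 20000 nM in this assay, at which 1 of the 2 values shown sits; this is a limit of the assay and not a number, so compound 2 sits at the weak end of what is shown, with no step between the two measured compounds that can be sized.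

The unmeasured compound 3, `COc1ncnc2c1c(-c1ccco1)cn2[C@@H]1O[C@H](CO)[C@@H](O)[C@H]1O`, differs from compound 2 by hydrogen in place of amino on an aromatic carbon. With the amino group gone, compound 3 comes to resemble compound 1 in this respect, and compound 1 gives 440 nM in this assay. On that ground the step from compound 2 to compound 3 is expected to be large, toward stronger inhibition, at an at least 22-fold lower number from compound 2 to compound 3 (1.34 log units; beyond the scatter). Compound 3 is expected at about 900 nM, with a plausible range from 200 nM to 8000 nM.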

Compound 3, half-maximal inhibitory concentration: 40 nM
Beside the measured number, compound 3's estimate is 23-fold (1.35 log units) above it; measured number below the stated range.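

In this assay, with furan-2-yl held fixed, hydrogen in place of amino on the aromatic carbon between two ring nitrogen atoms gives an at least 500-fold lower number from compound 2 to compound 3 (2.69 log units; beyond the scatter) and so isolates this position as a strong determinant of the read-out, which compounds 1 and 2 could not do, as they differ in two places. The value of compound 2 is a limit of the assay and not a number, so the size of this step has no fixed upper end: the limit of > 20000 nM in this assay, at which 1 of the 3 values shown sits. With hydrogen on the shared core, furan-2-yl in place of thiophen-2-yl gives an 11-fold lower number from compound 1 to compound 3 (1.04 log units; beyond the scatter) in this assay, which shows that the aromatic substituent also moves the number substantially once the amino group is absent.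

From the compounds shown here alone, whether a methyl group or a chlorine atom on the carbon between the two ring nitrogen atoms would stay close to compound 3 or move toward compound 2 remains open. Also open, going by these compounds, are whether the amino step holds with thiophen-2-yl in place of furan-2-yl, and how a phenyl ring would compare with these two substituents.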